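The source may report more compounds than this note shows. Statements on the series, on what has been measured and on what is new or still open speak of the compounds shown alone.

Working notes on the series. Compound 2 `CCCCC(=O)N1N=C(c2cc(OC)ccc2N)SC1(C)C` gives 101% in an assay on isolated protein for inhibition of Nitric oxide synthase, inducible (Homo sapiens), read by scintillation counting, with a stated time of 30 min, tested at 50 uM (a higher number here means more inhibition at the concentration tested (going by the name of the read-out), a lower number less inhibition), and stands highest of the two numbers measured, the nearest being compound 1 `COc1ccc(N)c(C2=NN(C(C)=O)C(C)(C)S2)c1`, which gives 77.1%. Within the data shown here, the only step known within the pair is a number 23.9 percentage points higher from compound 1 to compound 2 (beyond the scatter), a modest gain beyond the scatter on lengthening the chain at the carbonyl. Compound 3 `COc1ccc(N)c(C2=NN(C(=O)C3CC3)C(C)(C)S2)c1` is not yet measured; it differs from compound 2 in one place: cyclopropyl in place of butyl on a carbonyl carbon. The measured step bears on this change only loosely, since it concerns growing the group on the carbonyl, whereas here a four-carbon chain gives way to a three-carbon ring. The number of compound 2 is already high, so little room for a rise remains; a small fall, plausibly within the scatter, is expected, giving a number 11 percentage points lower from compound 2 to compound 3 (beyond the scatter). For compound 3 the estimate is 90%, with the range 70% to 102%.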

Compound 3, a percentage reported as inhibition, at one concentration (the size of the read-out at that concentration, not a potency): 90.1%
Compound 3: the middle estimate sits 0.1 percentage points below what was measured; low and high end bracket the measured number.
By their numbers in this assay, from the lowest: compound 1; then compound 3; then compound 2.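

Cyclopropyl in place of butyl on the carbonyl carbon gives a number 10.9 percentage points lower from compound 2 to compound 3 (beyond the scatter), while cyclopropyl in place of methyl gives a number 13 percentage points higher from compound 1 to compound 3 (beyond the scatter). In this assay cyclopropyl therefore takes a middle place among the three groups, with methyl lowest and butyl highest, each gap lying beyond the scatter. The earlier pair held only open chains on the carbonyl carbon, whereas compound 3 shows that a ring at this place also keeps the number above that of the methyl group in compound 1.

From the compounds shown here alone, whether a longer chain, a branched chain such as isopropyl, a larger ring such as cyclohexyl or a phenyl ring would raise or lower the number here remains open. Nothing on hand accounts for the order of these three groups.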